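The source may report more compounds than this note shows. Statements on the series, on what has been measured and on what is new or still open speak of the compounds shown alone.

Measured compounds:
Compound 1, `COc1cc2c(Oc3ccc(NC(=O)c4cc(-c5ccc(F)cc5)ccn4)cc3F)ccnc2cc1OCCCN1CCCCC1`, gives 1240 nM in a functional assay on MKN-45 cells (Homo sapiens) for cytotoxicity, read by MTT assay, with a stated time of 72 h; on this read-out higher numbers stand for weaker inhibition and lower numbers for stronger inhibition.
Compound 2, `COc1cc2c(Oc3ccc(NC(=O)c4cc(-c5ccccc5C)ccn4)cc3F)ccnc2cc1OCCCN1CCN(C)CC1`, gives 240 nM in this assay.

Of the two numbers shown, compound 2 stands at the lower one; the only neighbour, compound 1, sits markedly higher, and the gap between them lies beyond the usual scatter. For the measured compounds named here, compound 1 and compound 2 differ in more than one place, so no single step between them can be read off.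

Compound 3, `COc1cc2c(Oc3ccc(NC(=O)c4cc(-c5ccc(F)cc5)ccn4)cc3F)ccnc2cc1OCCCN1CCN(C)CC1`, is not yet measured. It differs from compound 2 by 4-fluorophenyl in place of 2-methylphenyl on an aromatic carbon. Compound 1 carries the same 4-fluorophenyl group, though with a different chain end, and that resemblance makes a weakening step from compound 2 plausible. The step of a 2.1-fold higher number from compound 2 to compound 3 (0.32 log units; beyond the scatter) in this assay is therefore expected to be moderate and upward, not clearly beyond the scatter. For compound 3 the estimate in this assay is 500 nM, with a range from 150 nM to 1500 nM.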

Compound 3, half-maximal inhibitory concentration: 510 nM
Compound 3: middle estimate off by 1.0-fold (0.01 log units), on the low side, within the range that was stated.
By their numbers in this assay, from the lowest: compound 2; then compound 3; then compound 1.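

In this assay, the change at the aromatic carbon opposite the ring nitrogen can now be read on its own: with the 4-methylpiperazin-1-yl chain end held fixed, 4-fluorophenyl in place of 2-methylphenyl gives a 2.1-fold higher number from compound 2 to compound 3 (0.33 log units; beyond the scatter) as a modest step. With 4-fluorophenyl held fixed, the chain end also shows its own effect: 4-methylpiperazin-1-yl in place of piperidin-1-yl gives a 2.4-fold lower number from compound 1 to compound 3 (0.39 log units; beyond the scatter) in the same assay, so each of the two places moves the number separately. No measurement offered here accounts for either step.

The compounds shown leave open whether the methyl group, the fluorine or the place of either drives the first step, as they include no unsubstituted phenyl, 4-methylphenyl or 2-fluorophenyl. They also leave open how a morpholin-4-yl chain end would compare.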